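Phenyl for isopropyl on the arylpiperazine of compound 2

The compounds below may be only part of what the source reports. "The series", "measured", "known", "first", "only" and "open" are said of these compounds alone.

Compound 1, `NC(=O)[C@@H]1Cc2ccccc2CN1C(=O)CCCCCN1CCN(c2ccccc2-c2ccccc2)CC1`, 10 nM in an assay on HEK293 cells for displacement of a labelled ligand from 5-hydroxytryptamine receptor 7 (Homo sapiens), with a stated time of 1 h; on this read-out higher numbers stand for weaker inhibition and lower numbers for stronger inhibition
Compound 2, `CC(C)c1ccccc1N1CCN(CCCCCC(=O)N2Cc3ccccc3C[C@H]2C(=O)N2CCCCC2)CC1`, 40 nM

Of the compounds shown here, two have been measured in this assay. Compound 1 gives 10 nM, the lower of the two numbers, and compound 2 gives 40 nM, the higher; the gap between them is beyond the scatter. For the measured compounds named here, the two differ in more than one place, so no single-change step connects them.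

Compound 3, `O=C([C@@H]1Cc2ccccc2CN1C(=O)CCCCCN1CCN(c2ccccc2-c2ccccc2)CC1)N1CCCCC1`, has not yet been measured in this assay. It differs from compound 2 in one place: phenyl in place of isopropyl on an aromatic carbon. With this change compound 3 carries the same aryl group on the piperazine as compound 1, while keeping the piperidine amide of compound 2.

No measured step isolates this change, so the direction can only be guessed from the two numbers shown. Compound 3 is expected to bind somewhat more strongly than compound 2, a step of a 2.0-fold lower number from compound 2 to compound 3 (0.30 log units; within the scatter), of modest size. The estimate for compound 3 in this assay is 20 nM, within a range from 6 nM to 60 nM.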

Compound 3, inhibition constant: 9 nM
For compound 3 the middle estimate is 2.2-fold (0.35 log units) above the measured one; measured number inside the range.
By their numbers in this assay, from the lowest: compounds 3 and 1 (each within the scatter of the next); then compound 2.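

In this assay, for the compounds shown here, the change from 2-isopropylphenyl to 2-phenylphenyl on the piperazine gives a 4.4-fold lower number from compound 2 to compound 3 (0.65 log units; beyond the scatter) and so provides the first direct reading of this change at an aromatic carbon, with the larger aromatic group on the side of stronger binding in this single pair. Going by these compounds alone, the other new step, a 1.1-fold lower number from compound 1 to compound 3 (0.05 log units; within the scatter) for the swap on the carbonyl carbon, shows that piperidin-1-yl and amino cannot be told apart here when the 2-phenylphenyl group is present, so of the two steps only the one at the aromatic carbon lies beyond the scatter. No data on hand offer an explanation for either step.

As far as these compounds go, what remains open is whether the change from isopropyl to phenyl would give a step of similar size with amino on the carbonyl carbon, as isopropyl appears here only with piperidin-1-yl. Also open, from the compounds shown here alone, is how other groups would read at this aromatic carbon, such as methyl, cyclohexyl or a pyridyl ring, and whether morpholin-4-yl on the carbonyl carbon would likewise stay within the scatter.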